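The compounds below may be only part of what the source reports. "The series", "measured", "known", "first", "only" and "open" are said of these compounds alone.

Values measured in a functional assay on A-375 cells (Homo sapiens) for antiproliferative activity, read by MTT assay, with a stated time of 72 h; a lower number here means a stronger inhibitor, a higher number a weaker inhibitor:

- Compound 1 `O=C1COc2ccc(-c3cccc(NS(=O)(=O)c4ccc(F)cc4)c3)cc2N1`: 20100 nM
- Compound 2 `COc1cccc(N2C(=O)COc3ccc(-c4cccc(NS(=O)(=O)c5ccc(F)cc5)c4)cc32)c1`: > 40000 nM, a limit of the assay
- Compound 3 `CC(C)N1C(=O)COc2ccc(-c3cccc(NS(=O)(=O)c4ccc(F)cc4)c3)cc21`: > 40000 nM, a limit of the assay

Compound 3 stands at the limit of > 40000 nM in this assay, at which 2 of the 3 values shown sit, so its result is a limit and not a number. Setting it against the other limit gives a step that the two limits leave unreadable from compound 2 to compound 3.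

The next compound, compound 4 `O=C1COc2ccc(-c3cccc(NS(=O)(=O)c4ccc(F)cc4)c3)cc2N1c1ccc(Cl)cc1`, has 4-chlorophenyl in place of isopropyl on an amide-type nitrogen in a ring.

Within the data shown here, two measured steps bear on this nitrogen. Replacing its hydrogen with 3-methoxyphenyl gave an at least 1.9-fold higher number from compound 1 to compound 2 (0.29 log units; that floor lies within the scatter), and replacing it with isopropyl gave an at least 1.9-fold higher number from compound 1 to compound 3 (0.29 log units; that floor lies within the scatter). On these data alone, both are only floors, so the true sizes remain unknown.

Compound 2, whose result is the limit > 40000 nM, also carries an aromatic ring on this nitrogen. Compound 4 is therefore expected to stay in the same weak region of this assay, with no clear move in either direction, and it may well end at the limit again. The expected change is a number no higher from compound 3 to compound 4 (the limit leaves the size open). For compound 4 the estimated value is 40000 nM, with an expected range from 15000 nM to 80000 nM.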

Compound 4, half-maximal inhibitory concentration: 32500 nM
Estimate against measurement, compound 4: 1.2-fold (0.09 log units) above; the range from low to high includes it.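

Among the compounds with a group on this nitrogen, compound 4 alone gives a number rather than a limit in this assay and so allows the first full reading of such a change: 4-chlorophenyl in place of hydrogen gives a 1.6-fold higher number from compound 1 to compound 4 (0.21 log units; within the scatter) and leaves the result in the same weak region as the unsubstituted compound. This shows that a group on this nitrogen, here one with a six-membered aromatic ring, does not necessarily cost activity beyond the usual scatter, which the earlier floors could not settle. Against the other two substituted compounds, the steps remain floors, with 4-chlorophenyl in place of isopropyl giving an at least 1.2-fold lower number from compound 3 to compound 4 (0.09 log units; that floor lies within the scatter) and 4-chlorophenyl in place of 3-methoxyphenyl giving an at least 1.2-fold lower number from compound 2 to compound 4 (0.09 log units; that floor lies within the scatter), so neither step ranks these groups, and compound 2 and compound 3 remain limits and not numbers: the limit of > 40000 nM in this assay, at which 2 of the 4 values shown sit.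

On these data alone, the true values of compound 2 and compound 3 stay unknown, so the order of the three groups on this nitrogen cannot be told. Also open, as far as these compounds go, is whether a short chain ending in an amine or a carboxylic acid at this place would give a clearly lower number than compound 1 does.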